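(2-Phenylethenyl)carbonyl in place of (chloromethyl)carbonyl

This account rests on a few compounds, and the source may have more. Where it says the series, first, only, none or still open, it means among the compounds named here.

Compound 1, `CCN(CC)c1ccc2cc(C(=O)c3ccc(N4CCN(C(=O)CN5CCNCC5)CC4)cc3)oc2c1`: in a functional assay on MCF7 cells (Homo sapiens) for cytotoxicity, read by MTT assay, with a stated time of 48 h (a higher number here means a weaker inhibitor, a lower number a stronger inhibitor), compound 1 gives 5340 nM.
Compound 2, `CCN(CC)c1ccc2cc(C(=O)c3ccc(N4CCN(C(=O)CN5CCN(C(=O)CCl)CC5)CC4)cc3)oc2c1`: in this assay compound 2 gives only a limit, > 40000 nM.

Compound 2 therefore stands at the upper limit of this assay, the weaker end of the two numbers shown, as noted by the limit of > 40000 nM in this assay, at which 1 of the 2 values shown sits. The step of an at least 7.4-fold higher number from compound 1 to compound 2 (0.87 log units; beyond the scatter) is the only measured one, and it concerns attaching the (chloromethyl)carbonyl to the ring amine, not the exchange now in question.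

Compound 3, `CCN(CC)c1ccc2cc(C(=O)c3ccc(N4CCN(C(=O)CN5CCN(C(=O)/C=C/c6ccccc6)CC5)CC4)cc3)oc2c1`, is not yet measured. It differs from compound 2 by 2-phenylethenyl in place of chloromethyl on a carbonyl carbon. Among the compounds with values here, no measured step bears directly on this change, and since compound 2 is known only as a limit, the size of an at least 1.6-fold lower number from compound 2 to compound 3 (0.20 log units; that floor lies within the scatter) is expected only loosely. Compound 3 is estimated at 25000 nM, within a range from 6000 nM to 60000 nM, with a substantial chance that this assay again reports only a limit for compound 3.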

Compound 3, half-maximal inhibitory concentration: 13400 nM
For compound 3 the middle estimate is 1.9-fold (0.27 log units) above the measured one; low and high end bracket the measured number.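

In this assay, the exchange on the carbonyl carbon gives an at least 2.9-fold lower number from compound 2 to compound 3 (0.47 log units; beyond the scatter), so the group carried by this carbonyl, and not the carbonyl alone, sets the read-out. Placing (2-phenylethenyl)carbonyl on the ring amine nitrogen still gives a 2.5-fold higher number from compound 1 to compound 3 (0.40 log units; beyond the scatter), and compound 1, with hydrogen on that nitrogen, remains the strongest of the three compounds. The full size of the exchange stays undetermined, since compound 2 is known only as a limit: the limit of > 40000 nM in this assay, at which 1 of the 3 values shown sits.

The compounds shown leave open whether the double bond or the aromatic ring accounts for the difference, a question that a saturated 2-phenylethyl group on the carbonyl would separate. They also leave open how an acetyl group or a simple methyl group on that nitrogen would compare with hydrogen.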